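Trimming the Benzyl Group of Compound 2 to Methyl

A few compounds are considered here, and "the series" means these few. Any claim that something is new, unique, unknown or untested is made for them only; others in the source may bear on it.

Among the measured compounds shown here, compound 2 `O=C1NC(=O)N(Cc2ccccc2)/C1=C\c1ccccc1` gives 42% in a functional assay on A549 cells (Homo sapiens) for antiproliferative activity, read by trypan blue exclusion, with a stated time of 72 h, tested at 20 uM (on this read-out higher numbers stand for more inhibition at the one concentration tested (going by the name of the read-out) and lower numbers for less inhibition), the higher of the two numbers known here; compound 1 `O=C1NC(=O)N(Cc2ccccc2)/C1=C/c1ccccc1` gives 2.9%, and a number 39.1 percentage points higher from compound 1 to compound 2 (beyond the scatter), which rests on (the fact that compounds 1 and 2 differ only in the configuration as drawn). Compound 3 `CN1C(=O)NC(=O)/C1=C/c1ccccc1` carries the change (hydrogen in place of phenyl on a saturated chain carbon bound to an amide-type nitrogen in a ring). For the measured compounds named here, no measured step touches this change, since the only known step concerns the double bond geometry alone, so the expected size of the step cannot be drawn from data; a modest drop is estimated, a number 12 percentage points lower from compound 2 to compound 3 (beyond the scatter). Compound 3 is therefore expected to give 30%, with a range from 5% to 55%.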

Compound 3, a percentage reported as inhibition, at one concentration (the size of the read-out at that concentration, not a potency): 16%
Compound 3: the middle estimate sits 14 percentage points above what was measured, and the stated range covers the measured number.
By their numbers in this assay, from the lowest: compound 1; then compound 3; then compound 2.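

Going from benzyl to methyl, which swaps phenyl for hydrogen on the saturated chain carbon, gives a number 26 percentage points lower from compound 2 to compound 3 (beyond the scatter). The earlier pair spoke only to double bond geometry, whereas this step shows that the group on the amide-type nitrogen in a ring also counts for the read-out. Nothing at hand explains the drop.

From the compounds shown here alone, it remains open whether the phenyl ring itself matters or whether a plain longer chain, such as butyl, would do as well. A cyclohexylmethyl group would ask the same question.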